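A methyl group added to a compound at the limit

The source may report more compounds than this note shows. Statements on the series, on what has been measured and on what is new or still open speak of the compounds shown alone.

In a functional assay on DU-145 cells (Homo sapiens) for antiproliferative activity, read by MTT assay, with a stated time of 48 h (on this read-out higher numbers stand for weaker inhibition and lower numbers for stronger inhibition), compound 1 `c1ccc(-c2nnc(-c3cn4ccccc4n3)o2)cc1` gives 23400 nM. Compound 2 `Brc1ccc(-c2nnc(-c3cn4ccccc4n3)o2)cc1` gives > 50000 nM, which is a limit of the assay and not a number. Compound 2 therefore stands at the limit of > 50000 nM in this assay, at which 1 of the 2 values shown sits.

Compound 3 `Cc1cccn2cc(-c3nnc(-c4ccc(Br)cc4)o3)nc12` carries one change from compound 2: methyl in place of hydrogen on an aromatic carbon, two atoms from the ring nitrogen. Among the compounds with values here, only one measured step comes close to this change: bromo in place of hydrogen gave an at least 2.1-fold higher number from compound 1 to compound 2 (0.32 log units; beyond the scatter). That step involved a different group at a different place, so it offers no direction for methyl. No step beyond the scatter is therefore expected in this assay. The estimated change is an at least 1.1-fold lower number from compound 2 to compound 3 (0.04 log units; that floor lies within the scatter). For compound 3 the expected value is 45000 nM, with an estimated range from 18000 nM to 80000 nM.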

Compound 3, half-maximal inhibitory concentration: 38900 nM
Compound 3: the middle estimate sits 1.2-fold (0.06 log units) above what was measured, within the range that was stated.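

Compound 2 stands at a limit of the assay and not at a number: the limit of > 50000 nM in this assay, at which 1 of the 3 values shown sits. With methyl on the aromatic carbon two atoms from the ring nitrogen, this assay gives a readable number for compound 3, 38900 nM, so this position accepts a methyl group without any loss that can be seen. Going by these compounds, the step is an at least 1.2-fold lower number from compound 2 to compound 3 (0.10 log units; that floor lies within the scatter), and with no number for compound 2 its true size stays unknown, so a real gain from the methyl group can be neither claimed nor ruled out.

The compounds shown leave open whether the same methyl group would change anything on compound 1, which carries hydrogen in place of the bromo group. They also leave open how an ethyl chain, an amine or a carboxylic acid on this same aromatic carbon would read in this assay.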